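Swapping trifluoromethyl for methoxy on the shared core

A few compounds are considered here, and "the series" means these few. Any claim that something is new, unique, unknown or untested is made for them only; others in the source may bear on it.

In an ADME assay on Vero cells (Chlorocebus sabaeus) for cytotoxicity, read by MTT assay, with a stated time of 96 h (on this read-out lower numbers stand for higher toxicity in this test and higher numbers for lower toxicity in this test), compound 1 `CC(=O)c1ccc2c(c1)nc(-c1ccccc1)n2C1CCCCC1` gives 80000 nM. Going by the values given here, compound 2 `CC(=O)c1ccc2c(c1)nc(-c1ccc(C(F)(F)F)cc1)n2C1CCCCC1` gives 35000 nM, the lower of the two numbers so far. Among the compounds with values here, the one measured step, a 2.3-fold lower number from compound 1 to compound 2 (0.36 log units; beyond the scatter), is trifluoromethyl in place of hydrogen on an aromatic carbon. Compound 3 `COc1ccc(-c2nc3cc(C(C)=O)ccc3n2C2CCCCC2)cc1` has yet to be measured in this assay. It has methoxy in place of trifluoromethyl on an aromatic carbon, para to a large group: methoxy in place of trifluoromethyl on an aromatic carbon. Within the data shown here, only that single measured step bears on this change, since it introduced the group that now leaves, and no measured compound carries methoxy. A step toward a higher number is therefore expected, no larger than the measured one and possibly within the scatter. The expected step is a 1.7-fold higher number from compound 2 to compound 3 (0.23 log units; within the scatter). For compound 3 the estimated value is 60000 nM, with an expected range from 30000 nM to 120000 nM.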

Compound 3, half-maximal cytotoxic concentration: 30000 nM
Compound 3: middle estimate off by 2.0-fold (0.30 log units), on the high side; the range from low to high includes it.
By their numbers in this assay, from the lowest: compounds 3 and 2 (each within the scatter of the next); then compound 1.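

In this assay the exchange of trifluoromethyl for methoxy on an aromatic carbon, para to a large group, comes out as a 1.2-fold lower number from compound 2 to compound 3 (0.07 log units; within the scatter) and does not separate the two groups at this position. Methoxy in place of hydrogen gives a 2.7-fold lower number from compound 1 to compound 3 (0.43 log units; beyond the scatter) and so lies on the same side of compound 1 as the trifluoromethyl step, which means that across these three compounds the gap goes with either group replacing hydrogen, not with which of the two is present. No measurement available here accounts for this result.

On these data alone, whether an amine, a carboxylic acid or a longer chain at this position would stay with these two groups remains open. As far as these compounds go, whether the same holds at other places on the shared core also stays open.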